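The source may hold more compounds than are shown below. What is called first, only, known or untested is meant among the compounds shown, and "the series" means these compounds.

Series notes. Compound 1 `O=C1CC(c2ccccc2Br)C(=O)N1CN1CCN(c2ccc(F)cc2)CC1` and compound 2 `O=C1CC(c2ccccc2Br)C(=O)N1CN1CCN(c2ccc(Cl)cc2)CC1` share one core and differ only in the halogen on the aryl group attached to the amine nitrogen in a ring. In a functional assay on the whole organism (strain CF-1 albino) with Mus musculus as the target, with a stated time of 4 h (on this read-out lower numbers stand for an effect already at smaller amounts and higher numbers for an effect only at larger amounts of compound), compound 1 gives 100 mg/kg, and compound 2 gives 300 mg/kg. Among the measured compounds shown here, compound 2 therefore stands at the highest of the two numbers so far; its only neighbour is compound 1, and the step between them, a 3.0-fold higher number from compound 1 to compound 2 (0.48 log units; beyond the scatter), is the single measured step.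

Compound 3 `O=C1CC(c2ccccc2Br)C(=O)N1CN1CCN(c2cccc(C(F)(F)F)c2)CC1` is not yet measured. It differs from compound 2 by 3-(trifluoromethyl)phenyl in place of 4-chlorophenyl on an amine nitrogen in a ring. For the measured compounds named here, no measured step exchanges the whole aryl group in this way; the one step available, chloro in place of fluoro, bears on it only loosely, and it gave a modest rise. With nothing closer to lean on, the expected step is no change at the digits printed from compound 2 to compound 3 (within the scatter), that is, no change beyond the scatter, with a wide margin on both sides. Compound 3 is estimated at 300 mg/kg in this assay, with a range from 100 mg/kg to 1000 mg/kg.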

Compound 3, minimum effective dose: 300 mg/kg
For compound 3 middle estimate and measured number coincide at the digits printed, and the stated range covers the measured number.
By their numbers in this assay, from the lowest: compound 1; then compounds 2 and 3 (each within the scatter of the next).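

In this assay, exchanging 4-chlorophenyl for 3-(trifluoromethyl)phenyl on the amine nitrogen in a ring gives no change at the digits printed from compound 2 to compound 3 (within the scatter), so this place accepts a different aryl group with more heavy atoms without a shift that can be read, and compound 2 and compound 3 cannot be told apart. Measured against 4-fluorophenyl, the same entering group gives a 3.0-fold higher number from compound 1 to compound 3 (0.48 log units; beyond the scatter), a step of the same printed size as a 3.0-fold higher number from compound 1 to compound 2 (0.48 log units; beyond the scatter), which leaves compound 1 with the lowest number of the three and shows that the earlier separation from 4-fluorophenyl was not confined to the chloro exchange. Nothing at hand explains why these three aryl groups fall as they do.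

The step from compound 2 to compound 3 alters both the substituent and its place on the phenyl ring, so the two contributions stay unseparated, and 4-(trifluoromethyl)phenyl or 3-chlorophenyl would be needed to divide them. From the compounds shown here alone, whether a plain phenyl or a 4-methoxyphenyl group would fall with compound 1 or with compound 2 and compound 3 also remains open.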